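Pyridylmethyl side chain: pyridin-2-yl to pyridin-3-yl

The source may report more compounds than this note shows. Statements on the series, on what has been measured and on what is new or still open speak of the compounds shown alone.

Compound 1 `CC(C)(N)CCCN(C[C@H]1Cc2ccccc2CN1)[C@H]1CCCc2cccnc21` in a functional assay on cells for agonist activity at C-X-C chemokine receptor type 4 (Homo sapiens), read by fluorescence and calcium flux, with a stated time of 90 s (on this read-out higher numbers stand for an effect only at larger amounts of compound and lower numbers for an effect already at smaller amounts), gives > 30000 nM. Compound 2 `C(=C/CN(C[C@H]1Cc2ccccc2CN1)[C@H]1CCCc2cccnc21)\CNCc1ccccn1` in this assay gives > 30000 nM.

The value of compound 1 is a limit of the assay, not a number. The value of compound 2 is likewise a limit and not a number. the limit of > 30000 nM in this assay, at which 2 of the 2 values shown sit, therefore covers everything measured so far in this series, so compound 2 cannot be placed relative to compound 1 beyond saying that both sit at the limit.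

Among the compounds with values here, the one change measured so far, from compound 1 to compound 2, is a step that the two limits leave unreadable from compound 1 to compound 2; it gives no readable size and no direction.

Compound 3 `C(=C/CN(C[C@H]1Cc2ccccc2CN1)[C@H]1CCCc2cccnc21)\CNCc1cccnc1` differs from compound 2 by pyridin-3-yl in place of pyridin-2-yl on a saturated chain carbon bound to an amine nitrogen. Within the data shown here, no measured step bears on this change: the only step recorded is unreadable, and no pair of readable numbers exists. The expectation for the step from compound 2 to compound 3 is therefore a limit again rather than a sized step, a number no higher from compound 2 to compound 3 (the limit leaves the size open). For compound 3 the estimate in this assay is 30000 nM, with a range of 10000 nM to 100000 nM, most likely reported only as a limit.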

Compound 3, half-maximal effective concentration: > 30000 nM
Compound 3 ended at the assay's limit (the forecaster's own chance of this, stated with the estimate: 80%); the middle value lies on the limit itself.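

Compound 1, compound 2 and compound 3 all give a limit rather than a number in this assay, so no new step can be read among them: the limit of > 30000 nM in this assay, at which 3 of the 3 values shown sit.

The compounds shown leave open whether pyridin-3-yl in place of pyridin-2-yl changes agonist activity at all, and how far any of the three lies beyond the limit.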